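A few compounds are considered here, and "the series" means these few. Any claim that something is new, unique, unknown or untested is made for them only; others in the source may bear on it.

In an assay on HEK293 cells for displacement of a labelled ligand from NPC1-like intracellular cholesterol transporter 1 (Homo sapiens) (on this read-out lower numbers stand for stronger inhibition and higher numbers for weaker inhibition), compound 2 `CC1(C)CC(OC(=O)CN2CN(c3ccccc3)C3(CCN(C(=O)c4ccc(C(C)(C)C)cc4)CC3)C2=O)CC(C)(C)N1` gives 1300 nM, the lowest of the three numbers, and its gaps to the other two lie beyond the scatter. For the measured compounds named here, compound 1 `CC(C)(C)OC(=O)NCCCCNC(=O)CN1CN(c2ccccc2)C2(CCN(C(=O)c3ccc(C4CCCCC4)cc3)CC2)C1=O` gives 4600 nM and compound 3 `CS(=O)(=O)N1CCN(C(=O)CN2CN(c3ccccc3)C3(CCN(C(=O)c4ccc(C5CCCCC5)cc4)CC3)C2=O)CC1` gives 6300 nM; each of them differs from compound 2 in more than one place, so no single step connects them. Compound 4 `CC(C)(C)c1ccc(C(=O)N2CCC3(CC2)C(=O)N(CC(=O)N2CCC(CCO)CC2)CN3c2ccccc2)cc1` differs from compound 2 by 4-(2-hydroxyethyl)piperidin-1-yl in place of (2,2,6,6-tetramethylpiperidin-4-yl)oxy on a carbonyl carbon. Going by the values given here, no step of this kind has been measured. A moderate loss is expected here, with an estimated step of a 2.3-fold higher number from compound 2 to compound 4 (0.36 log units; beyond the scatter), because compound 1 gives 4600 nM and compound 3 gives 6300 nM while carrying other groups at that carbonyl carbon. Compound 4 is therefore expected at 3000 nM, within a range from 1000 nM to 9000 nM.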

Compound 4, half-maximal inhibitory concentration: 2600 nM
Estimate against measurement, compound 4: 1.2-fold (0.06 log units) above; the range from low to high includes it.
By their numbers in this assay, from the lowest: compounds 2, 4, 1 and 3 (each within the scatter of the next, the first and the last beyond it).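

In this assay, for the compounds shown here, the first measured step at this carbonyl carbon is a 2.0-fold higher number from compound 2 to compound 4 (0.30 log units; within the scatter) and so cannot be told apart from no change. At this position, then, 4-(2-hydroxyethyl)piperidin-1-yl can stand in place of (2,2,6,6-tetramethylpiperidin-4-yl)oxy without a change that can be read, even though the groups differ in size and in how they attach to the carbonyl carbon. Nothing available explains why the two groups read alike. Still open, as far as these compounds go, is whether a group without a ring, such as dimethylamino, or a carboxylic acid on a longer chain would read the same at this carbonyl carbon.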